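The source may hold more compounds than are shown below. What is called first, only, known or untested is meant among the compounds shown, and "the series" means these compounds.

Measured in an ADME assay on microsomes from liver (Rattus norvegicus) for metabolic stability; a lower number here means that the compound disappears faster, a higher number that the compound lasts longer:
- Compound 1 `CC#C[C@@H](Cc1nnn[nH]1)c1ccc(OCc2ccc3scc(-c4cccnc4C)c3c2)cc1`: 0.183 h
- Compound 2 `CC#C[C@@H](Cc1nnn[nH]1)c1ccc(OCc2ccc3sc(F)c(-c4ccccc4C)c3c2)cc1`: 0.367 h
- Compound 3 `CC#C[C@@H](Cc1nnn[nH]1)c1ccc(OCc2ccc3scc(-c4ccc(OCCCS(C)(=O)=O)cc4C)c3c2)cc1`: 1.48 h

Compound 1 and compound 2 lie within the scatter of each other, at the low end of these three numbers. Compound 3 stands beyond the scatter from compound 1, with a higher number.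

Compound 4 `CC#C[C@@H](Cc1nnn[nH]1)c1ccc(OCc2ccc3scc(-c4cc(OCCOC)ccc4C)c3c2)cc1` has not yet been measured. It keeps the core of compound 1 but carries 5-(2-methoxyethoxy)-2-methylphenyl in place of 2-methylpyridin-3-yl on an aromatic carbon, two ring bonds from the ring sulfur (5-(2-methoxyethoxy)-2-methylphenyl in place of 2-methylpyridin-3-yl on an aromatic carbon).

Among the compounds with values here, no measured pair isolates this change, so the expectation is loose. The closest guide is compound 3, which also carries a chain-bearing phenyl group in that place and gives 1.48 h in this assay. The expected step is a 3.3-fold higher number from compound 1 to compound 4 (0.52 log units; beyond the scatter), upward and modestly beyond the scatter. For compound 4 the estimated half-life is 0.6 h, with an expected range of 0.2 h to 1.8 h.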

Compound 4, half-life: 0.367 h
Compound 4: the middle estimate sits 1.6-fold (0.21 log units) above what was measured; the range from low to high includes it.
By their numbers in this assay, from the lowest: compounds 1, 2 and 4 (each within the scatter of the next); then compound 3.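

Replacing 2-methylpyridin-3-yl with 5-(2-methoxyethoxy)-2-methylphenyl at this position gives a 2.0-fold higher number from compound 1 to compound 4 (0.30 log units; within the scatter) in this assay. The larger group, with its ether chain, therefore leaves the half-life within the scatter of the core of compound 1. Carrying a chain on the phenyl group at this place is thus not enough on its own to reach the number of compound 3, at 1.48 h, as compound 4 stands at 0.367 h. No measurement shown here accounts for this result.

On these data alone, compound 3 and compound 4 differ in both the end of the chain and its place on the phenyl ring, so it remains open which of these separates their numbers. As far as these compounds go, how an amine or a carboxylic acid at the end of the chain would behave also remains open.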